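A few compounds are considered here, and "the series" means these few. Any claim that something is new, unique, unknown or untested is made for them only; others in the source may bear on it.

Of the compounds shown here, two have been measured. Compound 1 `C#CCSc1nc(Nc2ccc(OC)cc2)c(C#N)c(-c2ccccc2)n1` gives 28400 nM in a functional assay on MGC-803 cells (Homo sapiens) for inhibition, read by MTT assay, with a stated time of 72 h; on this read-out higher numbers stand for weaker inhibition and lower numbers for stronger inhibition. Compound 2 `COc1ccccc1Nc1nc(SCc2cn(Cc3ccccc3Cl)nn2)nc(-c2ccccc2)c1C#N` gives 5800 nM, the lowest of the two numbers, and the gap to compound 1 lies beyond the scatter. Compound 3 `N#Cc1c(Nc2ccccc2)nc(SCc2cn(Cc3ccccc3Cl)nn2)nc1-c1ccccc1` differs from compound 2 in one place: hydrogen in place of methoxy on an aromatic carbon. Among the compounds with values here, no measured pair isolates this change, so compound 3 is expected to sit near compound 2, with a small move toward weaker inhibition, a 1.6-fold higher number from compound 2 to compound 3 (0.19 log units; within the scatter), that may not exceed the scatter. The estimate for compound 3 is 9000 nM, within 3000 nM to 27000 nM.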

Compound 3, half-maximal inhibitory concentration: > 64000 nM
Compound 3 gave a limit, no number (the forecaster's own chance of this, stated with the estimate: 5%); at least 7.1-fold (0.85 log units) between middle value and limit.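

In this assay, going from 2-methoxyphenyl to phenyl gives an at least 11-fold higher number from compound 2 to compound 3 (1.04 log units; beyond the scatter). Within the data shown here, the methoxy on this aromatic carbon, ortho to a large group, therefore matters far more than the earlier compounds could show. For compound 3 the reading is a limit of the assay, not a number, so the full size of the step stays unknown: the limit of > 64000 nM in this assay, at which 1 of the 3 values shown sits.

The compounds shown do not tell whether methoxy is specifically required here. An ethoxy, a hydroxy or a fluorine on the same carbon could keep the activity or lose it.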